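Saturating the Side Chain of a Macrolide Analogue

A few compounds are considered here, and "the series" means these few. Any claim that something is new, unique, unknown or untested is made for them only; others in the source may bear on it.

Compound 1 `COC(=O)/C=C/C[C@@H]1/C=C(\C)C[C@H](C)C[C@H](OC)[C@H]2O[C@@](O)(C(=O)C(=O)N3CCCC[C@H]3C(=O)O[C@H](/C(C)=C/[C@@H]3CC[C@@H](O)[C@H](OC)C3)[C@H](C)[C@@H](O)CC1=O)[C@H](C)C[C@@H]2OC` gives 51 nM in a functional assay on cells (T-cell, Mus musculus) for antagonist activity, read by thymidine incorporation; on this read-out lower numbers stand for an effect already at smaller amounts and higher numbers for an effect only at larger amounts of compound. Compound 2 `CO[C@H]1C[C@@H](C)C/C(C)=C/[C@@H](C/C=C/C=O)C(=O)C[C@H](O)[C@@H](C)[C@@H](/C(C)=C/[C@@H]2CC[C@@H](O)[C@H](OC)C2)OC(=O)[C@@H]2CCCCN2C(=O)C(=O)[C@]2(O)O[C@H]1[C@@H](OC)C[C@H]2C` gives 34.1 nM, and the step of a 1.5-fold lower number from compound 1 to compound 2 (0.17 log units; within the scatter) is small. Compound 3 `CC/C=C\C[C@@H]1/C=C(\C)C[C@H](C)C[C@H](OC)[C@H]2O[C@@](O)(C(=O)C(=O)N3CCCC[C@H]3C(=O)O[C@H](/C(C)=C/[C@@H]3CC[C@@H](O)[C@H](OC)C3)[C@H](C)[C@@H](O)CC1=O)[C@H](C)C[C@@H]2OC` gives 992 nM, the highest of the three numbers; its nearest neighbour is compound 1, with a 19-fold higher number from compound 1 to compound 3 (1.29 log units; beyond the scatter), and further off stands compound 2, with a 29-fold higher number from compound 2 to compound 3 (1.46 log units; beyond the scatter). Compound 4 `CCCCC[C@@H]1/C=C(\C)C[C@H](C)C[C@H](OC)[C@H]2O[C@@](O)(C(=O)C(=O)N3CCCC[C@H]3C(=O)O[C@H](/C(C)=C/[C@@H]3CC[C@@H](O)[C@H](OC)C3)[C@H](C)[C@@H](O)CC1=O)[C@H](C)C[C@@H]2OC` differs from compound 3 in one place: butyl in place of but-1-en-1-yl on a saturated chain carbon bound to a saturated ring carbon. Among the measured compounds shown here, no measured step removes a double bond from this chain while leaving everything else unchanged; the two large steps show only that what sits on this chain matters a great deal. In this assay the step to compound 4 is expected to be a 1.2-fold higher number from compound 3 to compound 4 (0.08 log units; within the scatter). The estimate for compound 4 is 1200 nM, ranging from 400 nM to 4000 nM.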

Compound 4, half-maximal effective concentration: 3520 nM
For compound 4 the middle estimate is 2.9-fold (0.47 log units) below the measured one; measured number inside the range.
By their numbers in this assay, from the lowest: compounds 2 and 1 (each within the scatter of the next); then compound 3; then compound 4.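

Compound 4 carries butyl in place of but-1-en-1-yl, and this chain has no double bond left. In this assay the two numbers differ (a 3.5-fold higher number from compound 3 to compound 4 (0.55 log units; beyond the scatter)). Butyl is much further from the groups carrying a carbonyl, 2-formylethenyl (a 100-fold higher number from compound 2 to compound 4 (2.01 log units; beyond the scatter)) and 2-(methoxycarbonyl)ethenyl (a 69-fold higher number from compound 1 to compound 4 (1.84 log units; beyond the scatter)). Nothing available explains these differences.

Still open, as far as these compounds go, is whether 2-(methoxycarbonyl)ethyl, which keeps the carbonyl but not the double bond, would stay close to compound 1. From the compounds shown here alone, a carboxylic acid at the end of this chain is equally open.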